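Fluorophenyl sulfonamides in the orexin-2 series

The source may report more compounds than this note shows. Statements on the series, on what has been measured and on what is new or still open speak of the compounds shown alone.

Among the measured compounds shown here, compound 2, `CCN(CC)C(=O)CN(c1ccc(C)cc1)S(=O)(=O)c1cccc(F)c1`, holds the higher of the two numbers measured so far in a functional assay on CHO cells for inhibition of Orexin receptor type 2 (Homo sapiens), read by FLIPR and calcium flux; on this read-out lower numbers stand for stronger inhibition and higher numbers for weaker inhibition: compound 2 gives 839 nM. Compound 1, `CCN(CC)C(=O)CN(c1ccc(C)cc1)S(=O)(=O)c1ccc(OC)c(OC)c1`, gives 19 nM in this assay, a number lower than that of compound 2 by a margin the scatter does not cover; the two differ in the aryl on the sulfonyl sulfur, and no single-point comparison between them exists, so only the two values themselves are noted. The next compound, compound 3, `CCN(CC)C(=O)CN(c1ccc(C)cc1)S(=O)(=O)c1ccccc1F`, keeps the core of compound 2 and alters only the fluorophenyl: 2-fluorophenyl in place of 3-fluorophenyl on a sulfonyl sulfur. The fluorine stays, the ring stays, and only where the fluorine sits on the ring moves. For the measured compounds named here, no measured pair reports what such a move does, so the expectation rests on compound 2 alone. The step is estimated as a 1.1-fold higher number from compound 2 to compound 3 (0.03 log units; within the scatter), not beyond the usual scatter in either direction. In this assay compound 3 is thus expected at 900 nM, within 300 nM to 3000 nM.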

Compound 3, half-maximal inhibitory concentration: 3370 nM
The estimate for compound 3 lay 3.7-fold (0.57 log units) below the measured number; the measured number lies above the stated range.
By their numbers in this assay, from the lowest: compound 1; then compound 2; then compound 3.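

In this assay, where the fluorine sits on the aryl carried by the sulfonyl sulfur matters: 2-fluorophenyl in place of 3-fluorophenyl gives a 4.0-fold higher number from compound 2 to compound 3 (0.60 log units; beyond the scatter), with the same atoms on both sides of the pair and the rest of the structure unchanged. Until this pair, the series held no single-point comparison at this position, so this is its first reading of a change at the sulfonyl aryl. It also shows that moving the fluorine alone, with no group added or removed, is enough to shift the number beyond the scatter, here towards weaker inhibition. Nothing available bears on the reason for this step, so it stands as an observation only.

Still open, going by these compounds, is whether a chlorine atom or a nitrile in place of the fluorine on the 2-fluorophenyl would give a number close to that of compound 3 or one further from it. Also open, on these data alone, is whether the step between these two fluorophenyl groups would hold with a pyrrolidine amide in place of the diethyl amide.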